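The compounds below may be only part of what the source reports. "The series", "measured", "known", "first", "only" and "open" are said of these compounds alone.

Measured compounds:
- compound 1, `N[C@H]1CC[C@H](Nc2c(C(=O)NCc3cccc(C(F)(F)F)c3)nc(Br)c3cccnc23)CC1`: "not determined" (no result reported)
- compound 2, `N[C@H]1CC[C@H](Nc2c(C(=O)NCc3ccc(F)cc3)nc(Br)c3cccnc23)CC1`: 7000 nM
- compound 3, `COc1ccc(CNC(=O)c2nc(Br)c3cccnc3c2N[C@H]2CC[C@H](N)CC2)cc1`: 3000 nM

Three compounds share one core, a secondary amine bearing a trans-diaminocyclohexane and a bromine, and differ only in the group on the amide nitrogen. In a functional assay on HCT-116 cells (Homo sapiens) for cytotoxicity, read by MTT assay, with a stated time of 72 h (on this read-out lower numbers stand for stronger inhibition and higher numbers for weaker inhibition), compound 1 has no result reported, compound 2 gives 7000 nM and compound 3 gives 3000 nM. Compound 3 therefore stands lowest of the two numbers available; its nearest neighbour is compound 2, and the step of a 2.3-fold lower number from compound 2 to compound 3 (0.37 log units; beyond the scatter) is a modest one that exceeds the scatter.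

Compound 4, `N[C@H]1CC[C@H](Nc2c(C(=O)Nc3ccccc3)nc(Br)c3cccnc23)CC1`, is not yet measured. It differs from compound 3 by phenyl in place of 4-methoxybenzyl on an amide-type nitrogen. For the measured compounds named here, no measured step bears directly on this change: the one step available concerns a substituent on the aromatic ring of a benzyl group, whereas here the benzyl group as a whole is exchanged for phenyl, and the methoxy is lost at the same time. Since the methoxy went with the lower number in compound 3, a move in the opposite direction is expected, though its size is uncertain. The step of a 2.7-fold higher number from compound 3 to compound 4 (0.43 log units; beyond the scatter) is the estimate, and compound 4 is expected to give 8000 nM in this assay, within a range from 2000 nM to 30000 nM.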

Compound 4, half-maximal inhibitory concentration: 2000 nM
Estimate against measurement, compound 4: 4.0-fold (0.60 log units) above, and the stated range covers the measured number.
By their numbers in this assay, from the lowest: compounds 4 and 3 (each within the scatter of the next); then compound 2.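

In this assay, for the compounds shown here, the earlier compounds varied only a substituent on the benzyl ring, whereas compound 4 tests the group on the amide-type nitrogen as a whole, and a 1.5-fold lower number from compound 3 to compound 4 (0.18 log units; within the scatter) shows that exchanging 4-methoxybenzyl for phenyl leaves the number unresolved from that of compound 3. The same exchange starting from 4-fluorobenzyl gives a 3.5-fold lower number from compound 2 to compound 4 (0.54 log units; beyond the scatter), so at this position the effect of moving to phenyl depends on the benzyl group it replaces, and neither the methoxy group nor a benzyl group is needed to reach the level of compound 3. No measurement on these compounds accounts for either step, so the data describe the two changes without explaining them.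

Each exchange removes the ring substituent and shortens the link to the ring in a single change, and an unsubstituted benzyl group would be needed to separate those two parts. Also open, as far as these compounds go, is how this position responds to a methoxy or fluoro group on the phenyl ring itself, to a longer chain such as 2-phenylethyl, or to an amine on that ring.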